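The source may report more compounds than this note shows. Statements on the series, on what has been measured and on what is new or still open speak of the compounds shown alone.

Of the compounds shown here, three built on one shared core have been tested in a functional assay on NCI-H226 cells (Homo sapiens) for inhibition, read by sulforhodamine B assay, with a stated time of 48 h, tested at 10 uM; on this read-out higher numbers stand for more inhibition at the one concentration tested (going by the name of the read-out) and lower numbers for less inhibition. Compound 1 `Fc1ccc(-c2cn3ccnc3c(-c3ccc4ncn(C5CCCCC5)c4c3)n2)cc1` gives 23.3%, compound 2 `c1cn2cc(-c3ccsc3)nc(-c3ccc4ncn(C5CCCCC5)c4c3)c2n1` gives 6.34%, and compound 3 `Clc1ccc(-c2cn3ccnc3c(-c3ccc4ncn(C5CCCCC5)c4c3)n2)cc1` gives 19.4%; compound 3 thus stands second highest of the three, close to compound 1 and further from compound 2. Replacing the fluorophenyl or chlorophenyl group by a thiophen-3-yl group gave a number 17 percentage points lower from compound 1 to compound 2 (beyond the scatter) and a number 13.1 percentage points higher from compound 2 to compound 3 (beyond the scatter), whereas exchanging one halogen for another gave only a number 3.9 percentage points lower from compound 1 to compound 3 (within the scatter). Compound 4 `Brc1ccc(-c2cn3ccnc3c(-c3ccc4ncn(C5CCCCC5)c4c3)n2)cc1` carries bromo in place of chloro on an aromatic carbon. Among the measured compounds shown here, the one step that bears on this, a number 3.9 percentage points lower from compound 1 to compound 3 (within the scatter), stayed within the scatter, so no shift beyond the scatter is expected in this assay. Compound 4 is therefore expected to give about 20%, between 8% and 32%. This amounts to an expected step of a number 0.6 percentage points higher from compound 3 to compound 4 (within the scatter).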

Compound 4, a percentage reported as inhibition, at one concentration (the size of the read-out at that concentration, not a potency): 23.3%
Compound 4: middle estimate off by 3.3 percentage points, on the low side; low and high end bracket the measured number.
By their numbers in this assay, from the lowest: compound 2; then compounds 3, 1 and 4 (each within the scatter of the next).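

With bromo on the aromatic carbon para to a large group, this assay shows a number 3.9 percentage points higher from compound 3 to compound 4 (within the scatter) and no change at the digits printed from compound 1 to compound 4 (within the scatter), so fluoro, chloro and bromo cannot be told apart at this position. The 4-bromophenyl group also stands clear of thiophen-3-yl, with a number 17 percentage points higher from compound 2 to compound 4 (beyond the scatter), so this gap now holds for all three halogens. No evidence is available on why the three halogens read alike. On these data alone, it remains open whether a non-halogen group at this position, such as methoxy or an amine, would shift the number beyond the scatter.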